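A few compounds are considered here, and "the series" means these few. Any claim that something is new, unique, unknown or untested is made for them only; others in the source may bear on it.

Measured so far in a functional assay on RS4-11 cells (Homo sapiens) for inhibition, read by CCK-8 assay, with a stated time of 48 h, tested at 20 uM; on this read-out lower numbers stand for less inhibition of growth and higher numbers for more inhibition of growth at the one concentration tested:
- compound 1 `Cc1ccc(S(=O)(=O)Oc2ccccc2/C=C(\C#N)C(=O)Nc2nnc(C)s2)cc1` gives 33%
- compound 2 `Cc1nnc(NC(=O)/C(C#N)=C/c2cccc(OS(C)(=O)=O)c2)s1` gives 33%
- compound 3 `Cc1ccc(S(=O)(=O)Oc2cccc(/C=C(\C#N)C(=O)Nc3nnc(C)s3)c2)cc1` gives 28%

Compound 3 at 28% stands level with compound 1 and compound 2, as all three numbers lie within the usual scatter of each other. Compound 4 `Cc1ccc(S(=O)(=O)Oc2cccc(/C=C(\C#N)C(=O)Nc3nnc(-c4ccccc4Cl)s3)c2)cc1` keeps the rest of compound 3 but carries 2-chlorophenyl in place of methyl on an aromatic carbon.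

Within the data shown here, no measured step changes the group at this place, so the evidence is indirect. Among the measured compounds shown here, the only measured step is a number 5 percentage points lower from compound 2 to compound 3 (within the scatter), on putting 4-methylphenyl in place of methyl on a sulfonyl sulfur. That swap of methyl for a larger aromatic group sits elsewhere in the molecule, yet it stayed within the scatter. A similar result is the best guess here, with no step beyond the scatter and wide uncertainty in either direction. The expected change is a number 7 percentage points higher from compound 3 to compound 4 (within the scatter) in this assay. Compound 4 is estimated at 35%, with an expected range from 18% to 60%.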

Compound 4, percent growth inhibition at one concentration: 44%
Estimate against measurement, compound 4: 9 percentage points below; the measured number falls inside the stated range.
By their numbers in this assay, from the lowest: compounds 3, 1 and 2 (each within the scatter of the next); then compound 4.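

The change from methyl to 2-chlorophenyl on the aromatic carbon of the five-membered ring gives a number 16 percentage points higher from compound 3 to compound 4 (beyond the scatter) in this assay, the only step shown that lies beyond the scatter. Among these compounds, the one earlier step, a number 5 percentage points lower from compound 2 to compound 3 (within the scatter), changed the group on the sulfonyl sulfur, so this ring position is the first place where swapping a group moves the number by more than the scatter. Nothing measured here explains why the 2-chlorophenyl group brings this rise.

The compounds shown leave open whether the rise comes from the phenyl ring itself or from its chlorine, which plain phenyl at this place would help to separate. They also leave open how an amine or a longer carbon chain at this position would read, and whether the same swap would raise the number in compound 2.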